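Same atoms, new joins on the carbonyl carbon

The compounds below may be only part of what the source reports. "The series", "measured", "known", "first", "only" and "open" are said of these compounds alone.

For the measured compounds named here, in an ADME assay on microsomes from liver (Homo sapiens) for metabolic stability, read by LC-MS, with a stated time of 30 min, tested at 1 uM (a higher number here means that more of the compound is left, a lower number that less of the compound is left), compound 1 (`O=C(NCc1ccc(S(=O)(=O)c2ccccc2)cc1)c1cn2ccnc2cn1`) gives 87% and sits within the usual scatter of the only other measured compound. That compound, compound 2 (`O=C(NCc1ccc(S(=O)(=O)c2cc(F)cc(F)c2)cc1)c1cc2ccncc2o1`), gives 77% in this assay and carries different groups, so the two cannot be ranked.

Compound 3 (`O=C(NCc1ccc(S(=O)(=O)c2ccccc2)cc1)c1cnc2nccn2c1`) has not been measured yet. It has the same atoms as compound 1, joined differently. The change is a group of 9 heavy atoms (6 carbon, 3 nitrogen; one five-membered aromatic ring with 2 hetero atoms, one six-membered aromatic ring with 2 hetero atoms) in place of a group of 9 heavy atoms (6 carbon, 3 nitrogen; one five-membered aromatic ring with 2 hetero atoms, one six-membered aromatic ring with 2 hetero atoms), on a carbonyl carbon and it sits on a carbonyl carbon whose other neighbours are an amide-type nitrogen.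

Going by the values given here, no measured pair isolates a change of this kind, so any forecast stays loose. Compound 1 at 87% and compound 2 at 77% both keep much of the compound intact with different groups on that carbonyl carbon. On that basis the expected step of a number 7 percentage points lower from compound 1 to compound 3 (within the scatter) is a small drop that stays within the scatter. For compound 3 the estimated value is 80% with an expected range from 60% to 94% in repeat measurements.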

Compound 3, percent of the compound remaining: 60%
Compound 3: the middle estimate sits 20 percentage points above what was measured, within the range that was stated.
By their numbers in this assay, from the lowest: compound 3; then compounds 2 and 1 (each within the scatter of the next).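

In this assay, joining the same atoms differently on the carbonyl carbon gives a number 27 percentage points lower from compound 1 to compound 3 (beyond the scatter) and so moves the result beyond the usual scatter. Compounds 1 and 2 differ in more than one place and could not show what this position does on its own, whereas compound 1 and compound 3 differ only in the group on this carbonyl carbon. The leaving and entering groups match in every count available, with the same heavy atoms, the same two aromatic ring sizes, the same hydrogen-bond donors and acceptors, and no net charge, so these counts alone do not tell the two groups apart in this assay, and nothing shown accounts for the difference.

This is a single pair, so it cannot show whether the same exchange would give a similar step in the presence of the two fluorine atoms carried by compound 2. It also leaves open how a simpler group on the carbonyl carbon, such as a plain phenyl ring or a pyridine ring, would compare with either fused group.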